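Methyl Added Ortho to Fluoro: Stability Notes

The compounds below may be only part of what the source reports. "The series", "measured", "known", "first", "only" and "open" are said of these compounds alone.

Measured so far:
compound 1 `CN1C(=O)COc2cc(Nc3cc4c(cn3)ncn4CC3CC3)cnc21`: > 1.66 h
compound 2 `Cc1nc(Nc2cnc3c(c2)OCC(=O)N3C)cc2c1ncn2CC1CC1`: > 1.66 h
compound 3 `CN1C(=O)COc2cc(Nc3cc4c(cc3F)ncn4CC3CC3)cnc21`: 0.533 h

In an ADME assay on microsomes from liver (Homo sapiens) for metabolic stability (a lower number here means that the compound disappears faster, a higher number that the compound lasts longer), compound 1 sits at a limit of the assay, > 1.66 h. Compound 2 likewise reaches a limit in this assay, > 1.66 h. Going by the values given here, compound 3 gives 0.533 h in this assay, the only actual number in the set. The difference between the core of compound 3 and the core of compound 1 is not broken down here.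

Compound 2 differs from compound 1 by methyl in place of hydrogen on an aromatic carbon; the step that the two limits leave unreadable from compound 1 to compound 2 cannot be read, since both ends sit at the limit of > 1.66 h in this assay, at which 2 of the 3 values shown sit. Compound 4 `Cc1c(F)c(Nc2cnc3c(c2)OCC(=O)N3C)cc2c1ncn2CC1CC1`, not yet measured, differs from compound 3 by methyl in place of hydrogen on an aromatic carbon. This is the same kind of change, not the same: in compound 2 the methyl sits on a six-membered aromatic ring with 1 nitrogen, next to the ring nitrogen, while in compound 4 it sits on a six-membered aromatic ring of carbon only, ortho to a fluoro group. With the earlier step unreadable, the estimate for compound 4 assumes a step of a 1.1-fold higher number from compound 3 to compound 4 (0.05 log units; within the scatter) that stays small. Compound 4 is expected near 0.6 h, between 0.25 h and 1.5 h.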

Compound 4, half-life: 0.65 h
Estimate against measurement, compound 4: 1.1-fold (0.03 log units) below, and the stated range covers the measured number.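

In this assay, methyl in place of hydrogen on an aromatic carbon gives a 1.2-fold higher number from compound 3 to compound 4 (0.09 log units; within the scatter), so on the core of compound 3 this change stays within the scatter. The same change from compound 1 to compound 2 cannot be read, and the two steps cannot be compared, since both of those compounds stand at a limit: the limit of > 1.66 h in this assay, at which 2 of the 4 values shown sit. Carrying the change from one core to the other is therefore neither confirmed nor refuted, and compound 4 speaks only for a methyl ortho to a fluoro group.

Open, going by these compounds, is how a different group on that aromatic carbon, such as an amine, a methoxy group or a longer chain, would read in this assay. Also open, on these data alone, is the size of the methyl step on the core of compound 1.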